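Replacing morpholin-4-yl on the sulfonyl sulfur

The source may report more compounds than this note shows. Statements on the series, on what has been measured and on what is new or still open speak of the compounds shown alone.

compound 1 `O=C(NCc1ccc(S(=O)(=O)C2CCCOC2)cc1)N1Cc2ccncc2C1` gives 32 nM
compound 2 `O=C(NCc1ccc(S(=O)(=O)N2CCOCC2)cc1)N1Cc2ccncc2C1` gives 68 nM

Going by the values given here, in a functional assay on A2780 cells (Homo sapiens) for cytotoxicity, read by sulforhodamine B assay, with a stated time of 72 h (on this read-out lower numbers stand for stronger inhibition and higher numbers for weaker inhibition), compound 2 gives 68 nM, the higher of the two numbers so far. The next structure is compound 3 `O=C(NCc1ccc(S(=O)(=O)N2CCC[C@@H](O)C2)cc1)N1Cc2ccncc2C1`, and the change is 3-hydroxypiperidin-1-yl in place of morpholin-4-yl on a sulfonyl sulfur. The shared core stays untouched. Among the compounds with values here, one measured step bears on this change: a 2.1-fold higher number from compound 1 to compound 2 (0.33 log units; beyond the scatter), a modest step beyond the scatter, for morpholin-4-yl in place of oxan-3-yl on a sulfonyl sulfur. Within the data shown here, a single step sets no trend, and no measured compound carries a hydroxyl group. A similarly modest move at most is therefore expected, with its direction open and only a slight lean towards lower numbers. The expected change is a 1.4-fold lower number from compound 2 to compound 3 (0.13 log units; within the scatter), which would not clearly exceed the scatter. For compound 3 the estimated value is 50 nM, with an expected range from 20 nM to 130 nM.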

Compound 3, half-maximal inhibitory concentration: 70 nM
For compound 3 the middle estimate is 1.4-fold (0.15 log units) below the measured one, and the stated range covers the measured number.
By their numbers in this assay, from the lowest: compound 1; then compounds 2 and 3 (each within the scatter of the next).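

In this assay the step is a 1.0-fold higher number from compound 2 to compound 3 (0.01 log units; within the scatter), so on a sulfonyl sulfur whose other neighbours are: aromatic carbon, 3-hydroxypiperidin-1-yl and morpholin-4-yl cannot be told apart here, even though the entering group adds a hydrogen-bond donor and a defined stereocentre. Against oxan-3-yl the step is a 2.2-fold higher number from compound 1 to compound 3 (0.34 log units; beyond the scatter), so the gap to compound 1 seen with morpholin-4-yl also holds for 3-hydroxypiperidin-1-yl. Nothing at hand accounts for either result.

Open, on these data alone, is how plain piperidin-1-yl or the opposite stereocentre of 3-hydroxypiperidin-1-yl would compare with compound 3, which would isolate the contribution of the hydroxyl group. Also open, as far as these compounds go, is whether a piperazin-1-yl group or a ring carrying a carboxylic acid on the sulfonyl sulfur would stay level with compound 3 or move away from it.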